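Swapping Methyl for Trifluoromethyl on the Benzyl Group

The source may report more compounds than this note shows. Statements on the series, on what has been measured and on what is new or still open speak of the compounds shown alone.

Measured compounds in a functional assay on MCF7 cells (Homo sapiens) for cytotoxicity, read by MTT assay, with a stated time of 72 h; on this read-out lower numbers stand for stronger inhibition and higher numbers for weaker inhibition:
Compound 1, `Cc1cc(-c2ccccc2)n(/C(N)=N/S(=O)(=O)c2cc(C)c(Cl)cc2SCc2ccccc2C)n1`: 80000 nM
Compound 2, `Cc1cc(S(=O)(=O)/N=C(\N)n2nccc2-c2ccccc2)c(SCc2ccccc2C)cc1Cl`: 23000 nM
Compound 3, `Cc1cc(-c2ccccc2)n(/C(N)=N/S(=O)(=O)c2cc(C)c(Cl)cc2SCc2ccccc2)n1`: 15000 nM

Compound 2 holds the second highest of the three numbers. Its nearest neighbour is compound 3, whose number is lower by a gap that stays within the usual scatter, so the two cannot be ranked. Its furthest neighbour is compound 1, and that gap is real: a 3.5-fold lower number from compound 1 to compound 2 (0.54 log units; beyond the scatter). The other measured step, a 5.3-fold lower number from compound 1 to compound 3 (0.73 log units; beyond the scatter), removes the methyl from the 2-methylbenzyl group of compound 1 and also gives a clearly lower number.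

Compound 4, `Cc1cc(S(=O)(=O)/N=C(\N)n2nccc2-c2ccccc2)c(SCc2ccccc2C(F)(F)F)cc1Cl`, is not yet measured. It differs from compound 2 in one place: trifluoromethyl in place of methyl on an aromatic carbon. Among the measured compounds shown here, this is the same benzyl position where the step from compound 1 to compound 3 took the methyl away, so that step shows the position tolerates change, but no measured pair exchanges methyl for trifluoromethyl anywhere. For the measured compounds named here, with only that indirect evidence, no step beyond the scatter is expected in either direction; the estimated step is a 1.2-fold lower number from compound 2 to compound 4 (0.06 log units; within the scatter). Compound 4 is therefore expected to give about 20000 nM, with a range from 6000 nM to 60000 nM.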

Compound 4, half-maximal inhibitory concentration: 21000 nM
Beside the measured number, compound 4's estimate is 1.1-fold (0.02 log units) below it; the measured number falls inside the stated range.
By their numbers in this assay, from the lowest: compounds 3, 4 and 2 (each within the scatter of the next); then compound 1.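

In this assay, among the compounds shown here, the step of a 1.1-fold lower number from compound 2 to compound 4 (0.04 log units; within the scatter) is the first direct comparison of trifluoromethyl with methyl on this benzyl ring, and it lies within the usual scatter. Trifluoromethyl brings 4 heavy atoms where methyl has 1, yet the 2-(trifluoromethyl)benzyl and 2-methylbenzyl versions cannot be told apart on this read-out, so this position, ortho to a large group, accepts the exchange on the core of compound 2, a finding limited to this one pair. No measurement shown here speaks to why the two compounds read alike.

The compounds shown leave open whether removing the methyl altogether would matter on the core of compound 2 as it does on the core of compound 1, where that removal is the only benzyl change with a step beyond the scatter. They also leave open how this position would respond to a group of a different kind, such as an amine, a carboxylic acid or a longer chain like propyl, and whether the same exchange would read alike with the group elsewhere on the benzyl ring.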